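Swapping the Halogenated Aryl Group: Predicting Compound 4

A few compounds are considered here, and "the series" means these few. Any claim that something is new, unique, unknown or untested is made for them only; others in the source may bear on it.

Three compounds share one core and differ only in the aryl group carried on an aromatic nitrogen. Compound 1 `COc1ccc(-n2cc(CN3C(=O)C[C@@H]4CC[C@@]3(C)C4(C)C)nn2)cc1` gives 50 nM in a functional assay on A549 cells (Homo sapiens) for inhibition, read by MTT assay, with a stated time of 24 h; a higher number here means a weaker inhibitor, a lower number a stronger inhibitor. Compound 2 `CC1(C)[C@H]2CC[C@]1(C)N(Cc1cn(-c3ccc(F)cc3)nn1)C(=O)C2` gives 230 nM in this assay, and compound 3 `CC1(C)[C@H]2CC[C@]1(C)N(Cc1cn(-c3cccc(Br)c3)nn1)C(=O)C2` gives 90 nM in this assay. Compound 3 therefore stands second highest of the three numbers: there is a 1.8-fold higher number from compound 1 to compound 3 (0.26 log units; within the scatter), and there is a 2.6-fold lower number from compound 2 to compound 3 (0.41 log units; beyond the scatter).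

Compound 4 `CC1(C)[C@H]2CC[C@]1(C)N(Cc1cn(-c3ccccc3Cl)nn1)C(=O)C2` has not yet been measured. It differs from compound 3 in one place: 2-chlorophenyl in place of 3-bromophenyl on an aromatic nitrogen. The 3-bromophenyl leaves and a 2-chlorophenyl enters on the same aromatic nitrogen.

Both measured steps that bear on this change alter the same aryl group, and both moved the number only modestly, one within and one just beyond the scatter. A similarly small step, with no clear direction, is therefore expected for compound 4 in this assay. For compound 4 the expected value is 120 nM, with a range from 50 nM to 300 nM. This estimate means that a 1.3-fold higher number from compound 3 to compound 4 (0.12 log units; within the scatter) is expected.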

Compound 4, half-maximal inhibitory concentration: 70 nM
Beside the measured number, compound 4's estimate is 1.7-fold (0.23 log units) above it, within the range that was stated.
By their numbers in this assay, from the lowest: compounds 1, 4 and 3 (each within the scatter of the next); then compound 2.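

The 2-chlorophenyl group fits with the two best aryl groups so far: in this assay there is (a 1.3-fold lower number from compound 3 to compound 4 (0.11 log units; within the scatter)) and (a 1.4-fold higher number from compound 1 to compound 4 (0.15 log units; within the scatter)), so compounds 1, 3 and 4 cannot be ranked, even though their aryl groups differ in substituent and in its place on the ring. Compound 2 goes against this grouping, with its 4-fluorophenyl group set apart by a step that lies beyond the scatter (a 3.3-fold lower number from compound 2 to compound 4 (0.52 log units; beyond the scatter)), so this position tolerates several aryl groups but not every one equally. Nothing shown here explains why the 4-fluorophenyl compound stands apart.

Within the data shown here, no pair here changes only the halogen or only its place on the ring, so the separate contributions of these two features remain open. Also open, as far as these compounds go, is how a plain phenyl, or a phenyl bearing an amine or a carboxylic acid, would behave on this nitrogen.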